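Removing the Benzoyl Ester from Compound 1

The source may report more compounds than this note shows. Statements on the series, on what has been measured and on what is new or still open speak of the compounds shown alone.

Measured compounds:
- compound 1 `O=C(O[C@H]1C[C@H](n2cc(F)c(=O)[nH]c2=O)O[C@@H]1COP(=O)(O)Oc1ccccc1)c1ccccc1`, 1270 nM
- compound 2 `CCCCCCCCCc1ccc(OP(=O)(O)OC[C@H]2O[C@@H](n3cc(F)c(=O)[nH]c3=O)C[C@@H]2OC(=O)c2ccccc2)cc1`, 39900 nM
- compound 3 `C[n+]1cccc(OP(=O)([O-])OC[C@H]2O[C@@H](n3cc(F)c(=O)[nH]c3=O)C[C@@H]2OC(=O)c2ccccc2)c1`, 5750 nM

In a functional assay on MRC5 cells (Homo sapiens) for cytotoxicity, read by MTT assay, with a stated time of 48 h (a lower number here means a stronger inhibitor, a higher number a weaker inhibitor), compound 1 stands lowest of the three, with compound 3 nearest and compound 2 furthest. Adding a nonyl to an aromatic carbon gave a 31-fold higher number from compound 1 to compound 2 (1.50 log units; beyond the scatter), and swapping the phenyl phosphate for a charged pyridinium phosphate gave a 4.5-fold higher number from compound 1 to compound 3 (0.66 log units; beyond the scatter). Both changes moved the number upward.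

Compound 4 `O=c1[nH]c(=O)n([C@H]2C[C@H](O)[C@@H](COP(=O)(O)Oc3ccccc3)O2)cc1F` differs from compound 1 as follows: hydrogen in place of benzoyl on an oxygen on a saturated carbon. No measured step touches this position, so neither of the shown steps bears on it directly; they show only that every change so far made from compound 1 has weakened the effect in this assay. A move of similar kind is therefore expected here, though its size is uncertain. Compound 4 is estimated at 4000 nM, within 1000 nM to 20000 nM, meaning an expected step of a 3.1-fold higher number from compound 1 to compound 4 (0.50 log units; beyond the scatter).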

Compound 4, half-maximal inhibitory concentration: 36700 nM
Beside the measured number, compound 4's estimate is 9.2-fold (0.96 log units) below it; measured number outside the range, above it.
By their numbers in this assay, from the lowest: compound 1; then compound 3; then compounds 4 and 2 (each within the scatter of the next).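

In this assay, changing benzoyloxy to hydroxy on the saturated carbon gives a 29-fold higher number from compound 1 to compound 4 (1.46 log units; beyond the scatter) and so brings a large change in the number. The earlier steps shown here altered only the aryl group on the phosphate, so they said nothing about this oxygen; this step shows that the benzoyl ester is far from a silent passenger in this assay, and that removing it alone is enough to lose most of the effect seen with compound 1. Nothing measured here explains the size of this step.

Only benzoyl and hydrogen are shown on this oxygen, so it remains open whether a smaller acetyl ester or a longer-chain ester would keep the lower number of compound 1. As far as these compounds go, it is also open whether removing the benzoyl would have a similar effect when the phosphate carries the nonyl-substituted phenyl of compound 2 or the pyridinium of compound 3.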